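This account rests on a few compounds, and the source may have more. Where it says the series, first, only, none or still open, it means among the compounds named here.

Measured so far in a functional assay on COLO 205 cells (Homo sapiens) for inhibition, read by sulforhodamine B assay, with a stated time of 48 h; a higher number here means a weaker inhibitor of growth, a lower number a stronger inhibitor of growth:
Compound 2, `COc1cc(-c2nn(-c3cccc(NC(=O)c4ccc(Cl)c(C(F)(F)F)c4)c3)cc2-c2ccncc2)ccc1Cl`: 23300 nM
Compound 1, `O=C(Nc1cccc(-n2cc(-c3ccncc3)c(-c3ccc(Cl)c(O)c3)n2)c1)Nc1ccc(Cl)c(Cl)c1`: 9490 nM
Compound 3, `O=C(Nc1cccc(-n2cc(-c3ccncc3)c(-c3ccc(Cl)c(O)c3)n2)c1)Nc1cc(C(F)(F)F)cc(C(F)(F)F)c1`: 1580 nM

In this assay compound 2 stands at the highest number of the three, so it is the weakest inhibitor of growth here; compound 1 sits lower and compound 3 lower still, both beyond the usual scatter. Compound 4, `COc1cc(-c2nn(-c3cccc(NC(=O)Nc4cccc(C(F)(F)F)c4)c3)cc2-c2ccncc2)ccc1Cl`, is not yet measured and differs from compound 2 in one place: (3-(trifluoromethyl)phenyl)amino in place of 4-chloro-3-(trifluoromethyl)phenyl on a carbonyl carbon. Going by the values given here, no pair of measured compounds differs by just this change, so no measured step can be quoted for it. A modest move toward a lower number in this assay seems plausible, though it could remain within the scatter. Compound 4 is expected to give about 7000 nM, within a range from 2500 nM to 20000 nM. The estimated step of a 3.3-fold lower number from compound 2 to compound 4 (0.52 log units; beyond the scatter) is a small gain in potency.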

Compound 4, concentration for total growth inhibition: 1750 nM
Beside the measured number, compound 4's estimate is 4.0-fold (0.60 log units) above it; measured number outside the range, below it.
By their numbers in this assay, from the lowest: compounds 3 and 4 (each within the scatter of the next); then compound 1; then compound 2.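

Going by these compounds alone, the change gives a 13-fold lower number from compound 2 to compound 4 (1.12 log units; beyond the scatter) in this assay, the first single-place comparison in this set, and it shows that the group on this carbonyl carbon strongly affects the read-out. Two things change together: the amino link enters, bringing a hydrogen-bond donor, and the chlorine leaves the ring. No measurement here explains the gain. Still open, as far as these compounds go, is which of these two parts carries the step, and how a methylene link in place of the amino link would read.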